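Aroyl exchange on the core of compound 3

A few compounds are considered here, and "the series" means these few. Any claim that something is new, unique, unknown or untested is made for them only; others in the source may bear on it.

Measured in a functional assay on KB cells (Homo sapiens) for cytotoxicity, read by MTT assay, with a stated time of 72 h; on this read-out higher numbers stand for weaker inhibition and lower numbers for stronger inhibition:
- compound 1 `COc1cc2ncnc(NNC(=S)NC(=O)c3ccccc3Cl)c2cc1OC` gives 3560 nM
- compound 2 `COc1cc2ncnc(NNC(=S)NC(=O)c3ccc(Cl)cc3)c2cc1OC` gives 4590 nM
- compound 3 `COc1ccccc1C(=O)NC(=S)NNc1ncnc2ccccc12` gives > 50000 nM

For compound 3 the value is a limit of the assay, not a number. Compound 4 `O=C(NC(=S)NNc1ncnc2ccccc12)c1ccc(Cl)cc1` keeps the core of compound 3 and differs only in 4-chlorophenyl in place of 2-methoxyphenyl on a carbonyl carbon. Going by the values given here, no measured step exchanges a 2-methoxyphenyl for a 4-chlorophenyl. Among the compounds with values here, the only measured step at the carbonyl carbon, a 1.3-fold higher number from compound 1 to compound 2 (0.11 log units; within the scatter), moves a chloro substituent on the other core and stays within the scatter, so it offers little guidance for this change. The starting point is itself uncertain, compound 3 sitting at the limit of > 50000 nM in this assay, at which 1 of the 3 values shown sits. Compound 4 is expected to remain weak, estimated at 40000 nM (range 12000 nM to 100000 nM). A step of an at least 1.2-fold lower number from compound 3 to compound 4 (0.09 log units; that floor lies within the scatter) is thus expected, with a fair chance that only a limit is reported again.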

Compound 4, half-maximal inhibitory concentration: 3940 nM
Compound 4: the middle estimate sits 10-fold (1.01 log units) above what was measured; the measured number lies below the stated range.
By their numbers in this assay, from the lowest: compounds 1, 4 and 2 (each within the scatter of the next). At a limit, above all of these: compound 3.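

In this assay, going by these compounds alone, 4-chlorophenyl in place of 2-methoxyphenyl on a carbonyl carbon gives an at least 12-fold lower number from compound 3 to compound 4 (1.10 log units; beyond the scatter), the first step at this position beyond the scatter. The group on the carbonyl carbon can therefore separate a measurable value from a limit on this core, which the chloro move on the other core did not show. Compound 3 stands at a limit, not a number, so the size of the step is only a floor: the limit of > 50000 nM in this assay, at which 1 of the 4 values shown sits.

On these data alone, it remains open whether the step comes from losing the 2-methoxyphenyl or from gaining the 4-chlorophenyl. An unsubstituted phenyl or a 4-methoxyphenyl on this core would separate the two.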